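This account rests on a few compounds, and the source may have more. Where it says the series, first, only, none or still open, it means among the compounds named here.

Compound 1 `C[C@H]1CC(Cl)=C([Si](C)(C)C)[C@@H](C2CCCCC2)O1`: 62000 nM
Compound 2 `CC[C@H]1CC(Cl)=C([Si](C)(C)C)[C@@H](C2CCCCC2)O1`: 91000 nM

Within the data shown here, in a functional assay on SW1573 cells (Homo sapiens) for antiproliferative activity (on this read-out higher numbers stand for lower toxicity in this test and lower numbers for higher toxicity in this test), compound 1 gives 62000 nM and compound 2 gives 91000 nM; the two lie within the usual scatter of each other, and the only measured step, a 1.5-fold higher number from compound 1 to compound 2 (0.17 log units; within the scatter), is small. Compound 3 `C[Si](C)(C)C1=C(Cl)C[C@H](C2CCCCC2)O[C@@H]1C1CCCCC1` differs from compound 2 by cyclohexyl in place of ethyl on a saturated ring carbon. Among the measured compounds shown here, no measured step covers the entry of a cyclohexyl at this position, and the one known step offers little guidance, so no shift beyond the scatter is expected in this assay. Compound 3 is estimated at 80000 nM (range 25000 nM to 250000 nM), a step of a 1.1-fold lower number from compound 2 to compound 3 (0.06 log units; within the scatter) that is expected to stay within the scatter.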

Compound 3, concentration lethal to 50% of the cells: 88000 nM
Estimate against measurement, compound 3: 1.1-fold (0.04 log units) below; measured number inside the range.
By their numbers in this assay, from the lowest: compounds 1, 3 and 2 (each within the scatter of the next).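

Cyclohexyl in place of ethyl on this saturated ring carbon, next to the ring oxygen, gives a 1.0-fold lower number from compound 2 to compound 3 (0.01 log units; within the scatter) in this assay, and cyclohexyl in place of methyl gives a 1.4-fold higher number from compound 1 to compound 3 (0.15 log units; within the scatter). A much larger group carrying a ring therefore enters here with no shift beyond the scatter, which the step from methyl to ethyl alone could not show. No supporting data bear on the reason for this result. Still open, going by these compounds, is whether an amine or a carboxylic acid at this position would shift the number. Also open, on these data alone, is how replacing the chloro group would read in this assay.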